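The source may report more compounds than this note shows. Statements on the series, on what has been measured and on what is new or still open speak of the compounds shown alone.

Compound 1, whose structure is `CCCCCCCCCCCCCCCCCCNC(=O)[C@H]1CSC(CCCCCCCCCCCC)N1`, carries a dodecyl chain on a saturated ring carbon of its five-membered core. Within the data shown here, in a functional assay on TSU-Pr1 cells for antiproliferative activity against TSU (Homo sapiens), read by sulforhodamine B assay (on this read-out higher numbers stand for weaker inhibition and lower numbers for stronger inhibition), compound 1 gives 10700 nM, the highest of the two numbers measured so far. Among the measured compounds shown here, the only comparison available is compound 2, with structure `CCCCCCCCCCCCCCCCCCNC(=O)[C@H]1CSC(c2ccc(N(C)C)cc2)N1`, in which a 4-(dimethylamino)phenyl replaces that dodecyl chain; in this assay compound 2 gives 3000 nM. That single change gave a 3.6-fold lower number from compound 1 to compound 2 (0.55 log units; beyond the scatter), a modest gain beyond the usual scatter.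

Compound 3, with structure `CCCCCCCCCCCCCCCCCCNC(=O)[C@H]1CSC(c2cccc(O)c2)N1`, has not yet been measured. Its difference from compound 1 is 3-hydroxyphenyl in place of dodecyl on a saturated ring carbon. For the measured compounds named here, this is the same kind of exchange as the one leading to compound 2, an aromatic ring in place of the long chain, though here the ring carries a hydroxyl rather than a dimethylamino group, and no measured pair speaks to that particular swap. Because a 3.6-fold lower number from compound 1 to compound 2 (0.55 log units; beyond the scatter) was seen for the related exchange, a comparable modest drop is expected, namely a 2.7-fold lower number from compound 1 to compound 3 (0.43 log units; beyond the scatter). Compound 3 is therefore estimated to give 4000 nM in this assay, within a range from 1500 nM to 12000 nM.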

Compound 3, half-maximal inhibitory concentration: 4000 nM
Beside the measured number, compound 3's estimate shows no gap at the digits printed, within the range that was stated.
By their numbers in this assay, from the lowest: compounds 2 and 3 (each within the scatter of the next); then compound 1.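

In this assay, the gain first seen with compound 2 now appears a second time on the same saturated ring carbon: a different aromatic group, 3-hydroxyphenyl, in place of dodecyl gives a similar result (a 2.7-fold lower number from compound 1 to compound 3 (0.43 log units; beyond the scatter)). The modest improvement over the long chain is therefore not tied to the dimethylamino group alone, though two aromatic examples are all there is to go on. Exchanging one aromatic group for the other leaves the result within the scatter (a 1.3-fold higher number from compound 2 to compound 3 (0.12 log units; within the scatter)), so these two rings, with different groups at different places on them, cannot be told apart on this read-out, and nothing available explains why either one outperforms the dodecyl chain.

The compounds shown leave open whether the aromatic ring itself is enough, which a plain phenyl group would test, and whether a shorter chain such as hexyl on this carbon would give a similar number. Also open, as far as these compounds go, is how a ring bearing a carboxylic acid or a primary amine would read, and so whether the group on the ring can matter here at all.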